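Nitro in Place of Hydroxyl Hydrogen: Forecast for Compound 4

The source may report more compounds than this note shows. Statements on the series, on what has been measured and on what is new or still open speak of the compounds shown alone.

Measured compounds:
Compound 1 `Cc1c(C)c2ccc(OCC3CCN(Cc4cccc(CO)c4)CC3)cc2oc1=O` gives 1900 nM in an assay for inhibition of Amine oxidase [flavin-containing] A (Homo sapiens), read by fluorescence, using microsomes, with a stated time of 30 min; on this read-out lower numbers stand for stronger inhibition and higher numbers for weaker inhibition.
Compound 2 `Cc1cc(=O)oc2cc(OCC3CCN(Cc4ccc(CO)cc4)CC3)ccc12` gives 11000 nM in this assay.
Compound 3 `Cc1cc(=O)oc2cc(OCC3CCN(Cc4cccc(CO)c4)CC3)ccc12` gives 3500 nM in this assay.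

Compound 1 holds the lowest of the three numbers. Its nearest neighbour is compound 3, a 1.8-fold higher number from compound 1 to compound 3 (0.27 log units; within the scatter); compound 2 is furthest, its value and that of compound 1 lying beyond the scatter of each other.

Compound 4 `Cc1c(C)c2ccc(OCC3CCN(Cc4cccc(CO[N+](=O)[O-])c4)CC3)cc2oc1=O` differs from compound 1 by nitro in place of hydrogen on an oxygen on a saturated carbon. Among the compounds with values here, none of the measured steps touches this oxygen: a 1.8-fold higher number from compound 1 to compound 3 (0.27 log units; within the scatter) concerns a methyl on the shared core, and a 3.1-fold lower number from compound 2 to compound 3 (0.50 log units; beyond the scatter) concerns the change from 4-(hydroxymethyl)phenyl to 3-(hydroxymethyl)phenyl. Neither bears directly on the new change. With no guide, compound 4 is expected to remain close to compound 1, with no step beyond the scatter, a 1.3-fold higher number from compound 1 to compound 4 (0.12 log units; within the scatter). Compound 4 is therefore estimated at 2500 nM in this assay, between 900 nM and 7000 nM.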

Compound 4, half-maximal inhibitory concentration: 230 nM
Compound 4: the middle estimate sits 11-fold (1.04 log units) above what was measured; the whole stated range lies above it.
By their numbers in this assay, from the lowest: compound 4; then compounds 1 and 3 (each within the scatter of the next); then compound 2.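

In this assay, within the data shown here, the oxygen on the saturated carbon proves a sensitive place: hydroxy to nitrooxy gives an 8.3-fold lower number from compound 1 to compound 4 (0.92 log units; beyond the scatter) and, unlike the earlier steps, which left this oxygen untouched, moves a compound well beyond the scatter. The step is also the largest shown in this series. No measurement given here accounts for it. Going by these compounds, whether the drop depends on nitrooxy itself remains open, since a methoxy, an acetoxy or an amine at this place could tell. On these data alone, it is also open whether 4-((nitrooxy)methyl)phenyl would follow the same course.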